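Amide for Trifluoromethyl on a Diarylamine Core

This account rests on a few compounds, and the source may have more. Where it says the series, first, only, none or still open, it means among the compounds named here.

Compound 1 `Cc1cc(CCC#N)cc(C)c1Oc1cc(Nc2ccc(C#N)cc2)c(N)cc1C(F)(F)F` was tested in an in vitro ADME assay on microsomes from liver (Homo sapiens) for metabolic stability, tested at 1 uM (on this read-out higher numbers stand for a longer-lived compound and lower numbers for a shorter-lived compound), where compound 1 gives 0.928 h. Its companion compound 2 `Cc1cc(/C=C/C#N)cc(C)c1Oc1cc(Nc2ccc(C#N)cc2)c(N)cc1C(F)(F)F` gives 0.75 h in this assay. Within the data shown here, compound 1 stands at the top of these two numbers, but the only measured step, a 1.2-fold lower number from compound 1 to compound 2 (0.09 log units; within the scatter), falls within the scatter, so the two compounds are not distinguished by this assay. Compound 3 `Cc1cc(CCC#N)cc(C)c1Oc1cc(Nc2ccc(C#N)cc2)c(N)cc1C(N)=O` has not yet been measured. Compound 3 differs from compound 1 in one place: carbamoyl in place of trifluoromethyl on an aromatic carbon. Among the measured compounds shown here, no measured step touches this place; the one step available concerns the 2-cyanoethenyl for 2-cyanoethyl exchange elsewhere on the shared core and cannot be carried over. Without a related step, the expected change in this assay from compound 1 to compound 3 is estimated at a 1.1-fold higher number from compound 1 to compound 3 (0.03 log units; within the scatter), that is, none beyond the scatter. Compound 3 is therefore expected to give about 1 h in this assay, within a range from 0.45 h to 2.2 h.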

Compound 3, half-life: 0.7 h
Beside the measured number, compound 3's estimate is 1.4-fold (0.15 log units) above it; low and high end bracket the measured number.
By their numbers in this assay, from the lowest: compounds 3, 2 and 1 (each within the scatter of the next).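

Among these compounds, the first measured change at this position, the aromatic carbon para to the (4-cyanophenyl)amino group, gives in this assay a 1.3-fold lower number from compound 1 to compound 3 (0.12 log units; within the scatter), so carbamoyl in place of trifluoromethyl leaves compound 3 not distinguished from compound 1. The exchange adds a hydrogen-bond donor and a hydrogen-bond acceptor to a place that had neither, yet the half-life does not move beyond the scatter. No measurement at hand gives a reason for this result.

Going by these compounds, whether a carboxylic acid or an amine on this aromatic carbon would also stay within the scatter remains open. So does whether carbamoyl would give the same result alongside the 2-cyanoethenyl group of compound 2, since this one pair is the only reading of the exchange.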